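Cyclohexyl for Methoxyphenyl on a Ring Amide Nitrogen

The source may hold more compounds than are shown below. What is called first, only, known or untested is meant among the compounds shown, and "the series" means these compounds.

Compound 1 `COc1cccc(N2C(=O)COc3ccc(-c4cnc(OC)c(NS(=O)(=O)c5ccc(F)cc5)c4)cc32)c1` carries a 3-methoxyphenyl on an amide-type nitrogen in a ring. In a functional assay on HCT-116 cells (Homo sapiens) for antiproliferative activity, read by MTT assay, with a stated time of 72 h (on this read-out lower numbers stand for stronger inhibition and higher numbers for weaker inhibition), compound 1 gives > 40000 nM, which is a limit of the assay rather than a number. Compound 2 `COc1ncc(-c2ccc3c(c2)N(C2CCCCC2)C(=O)CO3)cc1NS(=O)(=O)c1ccc(F)cc1` differs from it by cyclohexyl in place of 3-methoxyphenyl on an amide-type nitrogen in a ring. In this assay compound 2 also gives > 40000 nM, again a limit. The size of the step that the two limits leave unreadable from compound 1 to compound 2 cannot be read because of the limit of > 40000 nM in this assay, at which 2 of the 3 values shown sit. Compound 3 `COc1cccc(N2C(=O)COc3ccc(-c4cnc5ccccc5c4)cc32)c1` rests on a different core; the difference between the cores of compound 1 and compound 3 is not broken down here. In this assay, going by the values given here, compound 3 gives 8240 nM, the only number among the three. Compound 4 `O=C1COc2ccc(-c3cnc4ccccc4c3)cc2N1C1CCCCC1` differs from compound 3 by cyclohexyl in place of 3-methoxyphenyl on an amide-type nitrogen in a ring, the same change as between compound 1 and compound 2. Since a step that the two limits leave unreadable from compound 1 to compound 2 stays unreadable, the expected step of a 1.5-fold higher number from compound 3 to compound 4 (0.16 log units; within the scatter) is set close to no change, with wide room either way. Compound 4 is estimated at 12000 nM, between 4000 nM and 40000 nM.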

Compound 4, half-maximal inhibitory concentration: > 40000 nM
Compound 4: only a limit was reported; the forecaster's own chance of this, stated with the estimate: 25%; at least 3.3-fold (0.52 log units) between middle value and limit.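

In this assay, cyclohexyl in place of 3-methoxyphenyl on the amide-type nitrogen gives an at least 4.8-fold higher number from compound 3 to compound 4 (0.68 log units; beyond the scatter), so on the core of compound 3 the change weakens inhibition beyond the scatter. On these data alone, compound 4 gives > 40000 nM, which is a limit and not a number, so the full size of this step stays unknown. The same change on the core of compound 1 cannot be read, so the loss is seen on one core only and its transfer between cores is neither confirmed nor refuted, because both values on that core are limits: the limit of > 40000 nM in this assay, at which 3 of the 4 values shown sit.

As far as these compounds go, it remains open whether a benzyl group or a short chain ending in an amine on that nitrogen would give a number rather than a limit. The compounds shown also leave open whether either group would behave alike on both cores.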